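The compounds below may be only part of what the source reports. "The series", "measured", "known", "first", "only" and "open" are said of these compounds alone.

Measured so far in a physicochemical assay on cells (Homo sapiens), with a stated time of 18 h, tested at 10 uM; a higher number here means a weaker effect of the compound at the concentration tested, a lower number a stronger effect:
compound 1, `COc1cc(/C=N/N(C)c2nc3ccccc3s2)cc(OC)c1O`, gives 3%;
compound 2, `COc1cc(/C=N/Nc2nc3ccccc3s2)ccc1O`, gives 7%.

Within the data shown here, compound 2 stands highest of the two numbers, but its only neighbour, compound 1, lies within the usual scatter of it, so the two read-outs cannot be ordered. Both compounds give low activity read-outs in this assay, which on this scale means a strong effect at the concentration tested.

The next compound, compound 3, `COc1cc(/C=N/N(C)c2nc3ccccc3s2)ccc1O`, differs from compound 2 by methyl in place of hydrogen on a nitrogen on an aromatic ring. Among the measured compounds shown here, no pair of measured compounds isolates this change, so there is no measured step to lean on. For the measured compounds named here, compound 1 already carries the methyl on that nitrogen and additionally a second methoxy, and its read-out sits close to that of compound 2; this is the only guide. The expectation is therefore a step of a number 2 percentage points lower from compound 2 to compound 3 (within the scatter), that is, no change beyond the scatter in this assay. Compound 3 is estimated at 5%, with a range from 0% to 15%.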

Compound 3, a percentage reported as activity, at one concentration (the size of the read-out at that concentration, not a potency): 9%
Beside the measured number, compound 3's estimate is 4 percentage points below it; measured number inside the range.
By their numbers in this assay, from the lowest: compounds 1, 2 and 3 (each within the scatter of the next).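

The change of methyl in place of hydrogen on a nitrogen on an aromatic ring now has its own measured step in this assay, and that step is a number 2 percentage points higher from compound 2 to compound 3 (within the scatter) with no change beyond the scatter, so at this position the hydrogen and the methyl cannot be told apart by this read-out. Among these compounds, removing the other variable, hydrogen in place of methoxy on an aromatic carbon with the methyl on that nitrogen kept, gives a number 6 percentage points higher from compound 1 to compound 3 (within the scatter) and so this position, too, shows no separable change so far. Nothing on hand bears on a cause for either step.

As far as these compounds go, all three compounds give low read-outs, so it stays open whether a longer chain such as propyl on that nitrogen, or a carboxylic acid in place of the methoxy on an aromatic carbon, would move the number beyond the scatter. From the compounds shown here alone, it also stays open whether the two changes would act independently of each other on the shared core, since each has been read only as a single step within the scatter.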